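A Methyl on the Shared Core of Compound 1

The source may hold more compounds than are shown below. What is called first, only, known or untested is meant among the compounds shown, and "the series" means these compounds.

Compound 1 `CC(C)(C)OC(=O)N1CCC(Oc2ncnc3c2CCN3c2ccc(S(C)(=O)=O)cc2F)CC1` gives 20 nM in a functional assay on CHO-K1 cells for agonist activity at Glucose-dependent insulinotropic receptor (Homo sapiens), read by a luciferase reporter, with a stated time of 5 h; on this read-out lower numbers stand for an effect already at smaller amounts and higher numbers for an effect only at larger amounts of compound.
Compound 2 `CS(=O)(=O)c1ccc(N2CCc3c(OC4CCN(C(=O)OCCF)CC4)ncnc32)c(F)c1` gives 501 nM in this assay.
Compound 3 `CCS(=O)(=O)N1CCC(Oc2ncnc3c2CCN3c2ccc(S(C)(=O)=O)cc2F)CC1` gives 1580 nM in this assay.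

Compound 1 has the lowest number of the three. The steps away from it are a 25-fold higher number from compound 1 to compound 2 (1.40 log units; beyond the scatter) and a 79-fold higher number from compound 1 to compound 3 (1.90 log units; beyond the scatter), and the step of a 3.2-fold higher number from compound 2 to compound 3 (0.50 log units; beyond the scatter) separates the other two. All three of these steps change the group on the amine nitrogen in the piperidine ring.

Compound 4 `Cc1nc(OC2CCN(C(=O)OC(C)(C)C)CC2)c2c(n1)N(c1ccc(S(C)(=O)=O)cc1F)CC2` differs from compound 1 elsewhere: methyl in place of hydrogen on an aromatic carbon. Within the data shown here, no measured step touches this aromatic carbon, so no step among the measured compounds bears on this change, and the only anchor is the value of compound 1 in this assay. With nothing to suggest a shift in either direction, the step of a 1.5-fold higher number from compound 1 to compound 4 (0.18 log units; within the scatter) is expected to stay within the usual scatter. Compound 4 is therefore estimated at 30 nM in this assay, with a range from 8 nM to 120 nM that is widened to allow for the absence of any comparable change among the measured compounds.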

Compound 4, half-maximal effective concentration: 126 nM
Beside the measured number, compound 4's estimate is 4.2-fold (0.62 log units) below it; the measured number lies above the stated range.
By their numbers in this assay, from the lowest: compound 1; then compound 4; then compound 2; then compound 3.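

At the aromatic carbon between two ring nitrogen atoms, the shared core proves sensitive in this assay: methyl in place of hydrogen gives a 6.3-fold higher number from compound 1 to compound 4 (0.80 log units; beyond the scatter) with the tert-butoxycarbonyl group on the piperidine nitrogen left unchanged. Among these compounds, the earlier steps changed only the group on that amine nitrogen, so this is the first sign that a change on the shared core also moves the number beyond the scatter. Nothing available here accounts for the shift.

Going by these compounds, whether the rise belongs to methyl itself or would follow any replacement of hydrogen at this carbon stays open, and an amine, a methoxy group or a chlorine atom there would help to separate the two. On these data alone, it is also open whether the methyl has a similar effect with the (2-fluoroethoxy)carbonyl group of compound 2 or the ethylsulfonyl group of compound 3 on the amine nitrogen.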